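Replacing the Amide Side Chain: From Compound 3 to Compound 4

The compounds below may be only part of what the source reports. "The series", "measured", "known", "first", "only" and "open" are said of these compounds alone.

Of the compounds shown here, three built on one shared core have been tested in an ADME assay on HEK293 cells for agonist activity at metabotropic glutamate receptor 5 (Rattus norvegicus), read by fluorescence and calcium flux; a higher number here means a larger maximal response, a lower number a smaller maximal response. Compound 1 `Cc1cccc(C#Cc2ccc(C(=O)N[C@H](C)C(C)(C)O)nc2)c1` gives 20.8%. Going by the values given here, compound 2 `C[C@@H](NC(=O)c1ccc(C#CC2CCCC2)cn1)C(C)(C)O` gives 14.8%, and the only single-point step between measured compounds, a number 6 percentage points lower from compound 1 to compound 2 (within the scatter), stays within the scatter. Compound 3 `C[C@@H](NC(=O)c1ccc(C#Cc2cccc(F)c2)cn1)C(C)(C)C` gives 31.2%, which stands highest of the three numbers: compound 1 lies below it by more than the scatter, and compound 2 lies further below.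

Compound 4 `CC1(CCNC(=O)c2ccc(C#Cc3cccc(F)c3)cn2)COC1` differs from compound 3 in one place: 2-(3-methyloxetan-3-yl)ethyl in place of 1,2,2-trimethylpropyl on an amide-type nitrogen. Among the compounds with values here, this change sits on the amide-type nitrogen, a part of the molecule that the one measured step never touched, since that step altered only the group on the triple-bonded carbon and moved the number little. Within the data shown here, no measured step therefore bears directly on the change from compound 3 to compound 4; putting 2-(3-methyloxetan-3-yl)ethyl in place of 1,2,2-trimethylpropyl has no counterpart among the tested compounds, so its effect on maximal response is unknown here. The expectation is accordingly uncertain and kept modest, with the step estimated as a number 9.2 percentage points lower from compound 3 to compound 4 (within the scatter). Compound 4 is expected to give 22%, within a range from 8% to 40%.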

Compound 4, largest response reached (reported as efficacy), in percent of the reference or control that the assay uses: 16.3%
For compound 4 the middle estimate is 5.7 percentage points above the measured one; low and high end bracket the measured number.
By their numbers in this assay, from the lowest: compounds 2, 4 and 1 (each within the scatter of the next); then compound 3.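

In this assay, the amide-type nitrogen now has a measured step of its own: a number 14.9 percentage points lower from compound 3 to compound 4 (beyond the scatter) shows that the group held at this place can move the maximal response by more than the usual scatter. Going by these compounds alone, the only earlier step, a number 6 percentage points lower from compound 1 to compound 2 (within the scatter), changed the group on the triple-bonded carbon and gave no such clear shift, so this is the first single change here with a readable effect. The swap alters several things at once, taking away an open-chain group with a defined stereocentre and bringing in a longer group with a four-membered ring and a hydrogen-bond acceptor, and no available evidence indicates which of these differences lowers the response.

The compounds shown cannot separate the ring oxygen from the rest of the new group, a question that 2-(1-methylcyclobutyl)ethyl on the same nitrogen, with carbon in place of that oxygen, would address. Going by these compounds, it also remains open whether the same swap would lower the response to a similar extent with 3-methylphenyl or cyclopentyl on the triple-bonded carbon instead of the 3-fluorophenyl group of compound 3.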